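Changing the Aryl Group of Compound 1: What to Expect

The compounds below may be only part of what the source reports. "The series", "measured", "known", "first", "only" and "open" are said of these compounds alone.

Compound 1, `COc1cc(NC(=O)Nc2cc(Nc3ccc(C)c(C)c3)ncn2)cc(OC)c1`, was tested in a functional assay on HCC827 cells (Homo sapiens) for inhibition, read by MTT assay, with a stated time of 48 h, tested at 10 uM (a lower number here means less inhibition, a higher number more inhibition at the concentration tested (going by the name of the read-out)), and gave 45.7%. Among the three measured compounds this is the second highest number. Compound 2, `COc1cc(Br)ccc1Nc1cc(NC(=O)Nc2c(Cl)cccc2Cl)ncn1`, gives 42.7%, which lies within the usual scatter of the value of compound 1. Compound 3, `COc1ccc(OC)c(Nc2cc(NC(=O)Nc3c(Cl)cccc3Cl)ncn2)c1`, gives 94.1%, a number that stands beyond the scatter above compound 1. Compound 4, `COc1cc(NC(=O)Nc2cc(Nc3ccc(OC)c(I)c3)ncn2)cc(OC)c1`, has not yet been measured. It differs from compound 1 in a single place: 3-iodo-4-methoxyphenyl in place of 3,4-dimethylphenyl on a nitrogen on an aromatic ring. For the measured compounds named here, no measured pair shows this exact change, so its effect is not known from the data. A modest rise is expected, and the step of a number 9.3 percentage points higher from compound 1 to compound 4 (within the scatter) is estimated to lie near the edge of the scatter. Compound 4 is expected to give 55%, within a range from 25% to 85%.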

Compound 4, a percentage reported as inhibition, at one concentration (the size of the read-out at that concentration, not a potency): 61.7%
Compound 4: middle estimate off by 6.7 percentage points, on the low side, and the stated range covers the measured number.
By their numbers in this assay, from the lowest: compounds 2 and 1 (each within the scatter of the next); then compound 4; then compound 3.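

In this assay, 3-iodo-4-methoxyphenyl in place of 3,4-dimethylphenyl on a nitrogen on an aromatic ring gives a number 16 percentage points higher from compound 1 to compound 4 (beyond the scatter). For the compounds shown here, this is the first direct reading of a change at this position, and it shows that the number responds to the aryl group alone while the rest of compound 1 stays the same. No measurement at hand explains the rise.

As far as these compounds go, the iodine and the methoxy enter together, and their separate shares in the step remain open. Also open, from the compounds shown here alone, is how a carboxylic acid or a morpholine on this aryl group would read.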